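Dropping the Bromo Group: Expected Cytotoxicity of Compound 4

The source may hold more compounds than are shown below. What is called first, only, known or untested is meant among the compounds shown, and "the series" means these compounds.

Compound 1 `CCc1ccc(-c2nc3c(c(C)nn3-c3ccccc3)c(-c3ccccc3Br)c2C#N)cc1` was examined in an ADME assay on BJ cells (Homo sapiens) for cytotoxicity, with a stated time of 72 h; a lower number here means that less compound is needed, a higher number that more compound is needed for the effect. In this assay compound 1 gives only a limit, > 20000 nM. Two companions share its core and differ from it in a single group. Compound 2 `CCc1ccc(-c2nc3c(c(C)nn3-c3ccccc3)c(-c3ccccc3Cl)c2C#N)cc1` carries chloro in place of bromo on the aromatic carbon; in this assay compound 2 also reaches only a limit, > 20000 nM. Compound 3 `CCc1ccc(-c2nc3c(c(C)nn3-c3ccccc3)c(-c3ccccc3S(C)(=O)=O)c2C#N)cc1` carries methylsulfonyl at that carbon; in this assay compound 3 likewise reaches only a limit, > 20000 nM. The measured steps a step that the two limits leave unreadable from compound 1 to compound 2, a step that the two limits leave unreadable from compound 1 to compound 3 and a step that the two limits leave unreadable from compound 2 to compound 3 therefore cannot be sized, because of the limit of > 20000 nM in this assay, at which 3 of the 3 values shown sit.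

Compound 4 `CCc1ccc(-c2nc3c(c(C)nn3-c3ccccc3)c(-c3ccccc3)c2C#N)cc1` has not yet been measured. It differs from compound 1 by hydrogen in place of bromo on an aromatic carbon. Going by the values given here, none of the measured steps removes the halogen outright, yet every exchange at this carbon that has been tested, from bromo to chloro to methylsulfonyl, left the read-out at the limit. On that basis no readable step is expected for compound 4 in this assay, so the estimated change a step that the limit leaves unreadable from compound 1 to compound 4 is essentially none. The estimate for compound 4 is 30000 nM, within a range of 12000 nM to 100000 nM, with the measurement most likely again returning only a limit.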

Compound 4, half-maximal effective concentration: > 20000 nM
Compound 4 gave a limit, no number; the forecaster's own chance of this, stated with the estimate: 85%; the middle value is on the limit's open side.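

In this assay compound 4 also gives only a limit, > 20000 nM. Going by these compounds alone, no step between compound 4 and compounds 1, 2 or 3 can be read, because all four compounds share one limit: the limit of > 20000 nM in this assay, at which 4 of the 4 values shown sit. The compounds shown leave open where their actual values lie and whether any group at this aromatic carbon would give a readable number.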